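Adding a Second Chloro to a Meta-Linked Analogue

The source may hold more compounds than are shown below. What is called first, only, known or untested is meant among the compounds shown, and "the series" means these compounds.

Compound 1 `ClCc1ccccc1Cn1cnc2c(Cl)nc(Cl)nc21` and compound 2 `ClCc1ccccc1Cn1cnc2c(Cl)ncnc21` share one core, while compound 3 `ClCc1cccc(Cn2cnc3ncnc(Cl)c32)c1` is built from the same atoms joined differently; how the core of compound 3 differs from that of compound 2 is not broken down here. In a functional assay on OVCAR-3 cells (Homo sapiens) for cytotoxicity, read by sulforhodamine B assay, with a stated time of 48 h (a higher number here means that more compound is tolerated, a lower number that less compound is tolerated), compound 1 gives 1540 nM. In this assay compound 2 gives 8910 nM. In this assay compound 3 gives 43700 nM, the highest of the three measured numbers and beyond the scatter from both others.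

Within the measured set one single change is seen: chloro in place of hydrogen on an aromatic carbon. This change gave a 5.8-fold lower number from compound 2 to compound 1 (0.76 log units; beyond the scatter), a modest step.

Compound 4 `ClCc1cccc(Cn2cnc3nc(Cl)nc(Cl)c32)c1` has not yet been measured. Among the compounds with values here, it differs from compound 3 by chloro in place of hydrogen on an aromatic carbon, which is the same change, at a place described in the same words, as the one from compound 2 to compound 1. Within the data shown here, with only one example of this change measured, the expectation for compound 4 rests on that one step, and the different core of compound 3 leaves room for the step to differ in size.

The step expected from compound 3 to compound 4 in this assay is a 5.5-fold lower number from compound 3 to compound 4 (0.74 log units; beyond the scatter), estimated by carrying over a 5.8-fold lower number from compound 2 to compound 1 (0.76 log units; beyond the scatter). Compound 4 is thus expected to give about 8000 nM in this assay. For compound 4 the estimate is expected to fall between 3000 nM and 25000 nM.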

Compound 4, concentration lethal to 50% of the cells: 5370 nM
The estimate for compound 4 lay 1.5-fold (0.17 log units) above the measured number, within the range that was stated.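

In this assay the new step is an 8.1-fold lower number from compound 3 to compound 4 (0.91 log units; beyond the scatter) and it runs in the same direction as the step seen earlier, with chloro in place of hydrogen on an aromatic carbon giving the lower number on both cores. Set side by side, the two steps cannot be told apart in size: the same change on two cores in this assay, a 5.8-fold lower number (0.76 log units; beyond the scatter) from compound 2 to compound 1 and an 8.1-fold lower number (0.91 log units; beyond the scatter) from compound 3 to compound 4, 1.4-fold (0.15 log units) apart, within the scatter of two such steps. For these two pairs, then, the change carried from one core to the other with its direction and size intact, but two pairs in a single cell assay do not show that it would carry to any further core, and they give no reason why the number falls.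

The compounds shown hold only hydrogen or chloro on the aromatic carbon between two ring nitrogen atoms, so it remains open whether an amine, a methoxy group or a fluoro there would give a step like that of chloro. It also remains open whether the same step would hold if the chloromethyl group on the benzene ring gave way to a methyl group or a longer chain, since every compound shown carries that group.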